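Methoxy Added to a Phenyl Ring: Cytotoxicity Expectation

The source may report more compounds than this note shows. Statements on the series, on what has been measured and on what is new or still open speak of the compounds shown alone.

Compound 3 `CSc1ccc(-c2nc3sc(-c4ccc(F)cc4)nn3c2-c2ccccc2)cc1` has no result in an ADME assay on Vero cells (Chlorocebus sabaeus) for cytotoxicity, read by MTT assay, with a stated time of 72 h (a higher number here means a weaker inhibitor, a lower number a stronger inhibitor), where compound 3 stands only as "not determined" (no result reported); its standing there is simply unknown, as no number was reported. Compound 4 `COc1ccc(-c2c(-c3ccc(SC)cc3)nc3sc(-c4ccc(F)cc4)nn23)cc1` differs from it by methoxy in place of hydrogen on an aromatic carbon, a change that places a methoxy group on an aromatic carbon of a six-membered aromatic ring of carbon only.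

Two related compounds were measured. Compound 1 `COc1ccc(-c2c(-c3ccc(SC)cc3)nc3sc(C(F)(F)F)nn23)cc1` gives 123000 nM in this assay, and compound 2 `COc1ccc(-c2c(-c3ccc(SC)cc3)nc3sc(S(N)(=O)=O)nn23)cc1` gives 213000 nM. Among the measured compounds shown here, the one step between them, a 1.7-fold higher number from compound 1 to compound 2 (0.24 log units; within the scatter), concerns a different site of the shared core and does not touch the phenyl ring altered here. For the measured compounds named here, no measured step bears directly on the change from compound 3 to compound 4, so no direction can be read from the data, and compound 3 itself offers no starting point. What can be said is that compound 1 and compound 2, which both carry the same methoxyphenyl group that enters in compound 4, lie in the same region of this assay. Compound 4 is therefore expected to fall near them, at an estimated 150000 nM, with a range from 50000 nM to 400000 nM.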

Compound 4, half-maximal inhibitory concentration: 116000 nM
Estimate against measurement, compound 4: 1.3-fold (0.11 log units) above; the measured number falls inside the stated range.
By their numbers in this assay, from the lowest: compounds 4, 1 and 2 (each within the scatter of the next).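

In this assay compound 4 places 4-fluorophenyl on the aromatic carbon where compound 1 and compound 2 carry other groups, and both new steps stay within the scatter (a 1.8-fold lower number from compound 2 to compound 4 (0.26 log units; within the scatter)) and (a 1.1-fold lower number from compound 1 to compound 4 (0.03 log units; within the scatter)). The earlier compounds shown here showed only that trifluoromethyl and sulfamoyl could not be told apart at this carbon; with a phenyl-based group there as well, all three compounds now lie within the scatter of one another, so none of the three groups stands apart in this assay. No measurement bears on why these numbers lie together.

As far as these compounds go, compound 3 has no number, so the step to compound 4 cannot be read, and what methoxy in place of hydrogen does on this phenyl ring stays unknown, since all three compounds with numbers carry the same 4-methoxyphenyl group. Also open, from the compounds shown here alone, is whether an amine or a carboxylic acid on the carbon that varies here, or a hydroxy group or a longer chain such as ethoxy in place of methoxy, would give a number beyond the scatter of these three.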